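The source may report more compounds than this note shows. Statements on the series, on what has been measured and on what is new or still open speak of the compounds shown alone.

Measured compounds:
Compound 1, `Cc1ccc(-c2nn(-c3ccccc3)cc2C(=O)NOCc2ccc(Cl)cc2Cl)cc1`, gives 39600 nM in an ADME assay on HEK-293T cells (Homo sapiens) for antiproliferative activity, read by MTT assay, with a stated time of 48 h, in the presence of a further agent that is not named here; on this read-out higher numbers stand for lower toxicity in this test and lower numbers for higher toxicity in this test.
Compound 2, `O=C(NOCc1ccccc1)c1cn(-c2ccccc2)nc1-c1ccc(Cl)cc1`, gives 51900 nM in this assay.

Among the measured compounds shown here, compound 2 and compound 1 are the only two compounds with a number in this assay, and the gap between them lies within the usual scatter of repeated measurements, so compound 2 cannot be set apart from compound 1 on this read-out. Both sit at concentrations that count as weakly toxic in this test.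

Compound 3, `O=C(NOCc1ccc(Cl)cc1Cl)c1cn(-c2ccccc2)nc1-c1ccc(Cl)cc1`, has not yet been measured. It differs from compound 2 in one place: 2,4-dichlorophenyl in place of phenyl on a saturated chain carbon bound to an oxygen. For the measured compounds named here, no step between measured compounds matches this change exactly, but compound 1 already carries the 2,4-dichlorobenzyl group together with a different substituent on the shared core and gives 39600 nM, a number close to that of compound 2. On that basis the step from compound 2 to compound 3 is expected to be small, if anything a slight move toward higher toxicity, and not beyond the scatter, as a 1.4-fold lower number from compound 2 to compound 3 (0.16 log units; within the scatter) states. Compound 3 is therefore expected to give about 36000 nM in this assay, with a range of 15000 nM to 85000 nM.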

Compound 3, half-maximal cytotoxic concentration: 46300 nM
Estimate against measurement, compound 3: 1.3-fold (0.11 log units) below; the range from low to high includes it.
By their numbers in this assay, from the lowest: compounds 1, 3 and 2 (each within the scatter of the next).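

In this assay the exchange of phenyl for 2,4-dichlorophenyl on a saturated chain carbon bound to an oxygen can now be read directly as a 1.1-fold lower number from compound 2 to compound 3 (0.05 log units; within the scatter) and so stays within the scatter, which means that this position takes the two added chlorine atoms without a step that can be told apart from repeat measurement. The new compound also gives a second single-place comparison, chloro in place of methyl on an aromatic carbon, read as a 1.2-fold higher number from compound 1 to compound 3 (0.07 log units; within the scatter) and again within the scatter. Both places on the molecule have thus now been varied once each with no separable step in this test, and no information at hand bears on what lies behind these small steps.

The compounds shown leave open whether a group of another kind at the benzyl ring, such as an amine or a carboxylic acid, would give a step beyond the scatter. They also leave open what a longer chain in place of the benzyl carbon, or a methoxy group in place of the chloro on the aromatic carbon, would do in this test.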